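A few compounds are considered here, and "the series" means these few. Any claim that something is new, unique, unknown or untested is made for them only; others in the source may bear on it.

Measured compounds in a functional assay on HT-29 cells (Homo sapiens) for antiproliferative activity, read by MTT assay, with a stated time of 72 h; on this read-out lower numbers stand for stronger inhibition and higher numbers for weaker inhibition:
compound 1 `COc1cc2c(Oc3c(F)cc(NC(=O)NN4C(=O)CCSC4c4c(F)cccc4F)cc3F)ccnc2cc1OCCCN1CCCC1`: 270 nM
compound 2 `CCN1CCN(CCCOc2cc3nccc(Oc4c(F)cc(NC(=O)NN5C(=O)CSC5c5c(F)cccc5F)cc4F)c3cc2OC)CC1`: 73 nM
compound 3 `COc1cc2c(Oc3c(F)cc(NC(=O)NN4C(=O)CSC4c4c(F)cccc4F)cc3F)ccnc2cc1OCCCN1CCc2sccc2C1`: 1410 nM

Compound 3 gives the highest number of the three in this assay; compound 1 sits nearest to it and compound 2 furthest, both beyond the scatter. Among the measured compounds shown here, the single directly comparable step is a 19-fold higher number from compound 2 to compound 3 (1.29 log units; beyond the scatter), which shows that exchanging the group on the saturated chain carbon three bonds along the chain from the aromatic oxygen can move the read-out a great deal.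

Compound 4 `COc1cc2c(Oc3c(F)cc(NC(=O)NN4C(=O)CSC4c4c(F)cccc4F)cc3F)ccnc2cc1OCCCN1C[C@H]2CCCC[C@H]2C1` changes that same position again: a group of 9 heavy atoms (8 carbon, 1 nitrogen; one five-membered non-aromatic ring with 1 hetero atom, one six-membered non-aromatic ring of carbon only) in place of a group of 9 heavy atoms (7 carbon, 1 nitrogen, 1 sulfur; one five-membered aromatic ring with 1 hetero atom, one six-membered non-aromatic ring with 1 hetero atom), on a saturated chain carbon, three bonds along the chain from an oxygen on an aromatic ring. For the measured compounds named here, no measured pair covers this exchange, so the direction rests only on the fact that compound 3 holds the weakest value and that the two other variants at this position, compound 1 and compound 2, both give lower numbers. Going by the values given here, the expectation is therefore a step downward from compound 3, estimated as a 4.7-fold lower number from compound 3 to compound 4 (0.67 log units; beyond the scatter), with wide uncertainty because the group entering has no measured counterpart here. Compound 4 is expected at about 300 nM, within the range 80 nM to 1200 nM.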

Compound 4, half-maximal inhibitory concentration: 470 nM
For compound 4 the middle estimate is 1.6-fold (0.19 log units) below the measured one; the range from low to high includes it.
By their numbers in this assay, from the lowest: compound 2; then compounds 1 and 4 (each within the scatter of the next); then compound 3.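

In this assay, at the saturated chain carbon three bonds along the chain from an oxygen on an aromatic ring, exchanging the group with the five-membered aromatic ring for the one with a six-membered non-aromatic ring of carbon only gives a 3.0-fold lower number from compound 3 to compound 4 (0.48 log units; beyond the scatter), so the read-out shifts beyond the scatter even though both groups have 9 heavy atoms. The group of 8 heavy atoms with 2 nitrogen still gives the lowest number on this core, with a 6.4-fold higher number from compound 2 to compound 4 (0.81 log units; beyond the scatter), and both groups of 9 heavy atoms lie above it. No measurement available here accounts for either step.

On these data alone, whether a morpholine or a dimethylamino group at this place would approach compound 2 remains open. So does the effect of a longer chain, and that of the other stereoisomers of the group in compound 4.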